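The source may hold more compounds than are shown below. What is called first, only, known or untested is meant among the compounds shown, and "the series" means these compounds.

Compound 1 `O=C(Nc1cccc(-c2oc3cc(-c4ccc(F)cc4)ccc3c(=O)c2O)c1)c1ccc(F)cc1` gives 9280 nM in a functional assay on HepG2 cells (Homo sapiens) for antiproliferative activity, read by CCK-8 assay, with a stated time of 72 h; a higher number here means a weaker inhibitor, a lower number a stronger inhibitor. Compound 2 `Cc1ccc(C(=O)Nc2cccc(-c3oc4cc(-c5ccc(F)cc5)ccc4c(=O)c3O)c2)cc1` gives 2320 nM in this assay. Compound 3 `O=C(Nc1cccc(-c2oc3cc(-c4ccc(F)cc4)ccc3c(=O)c2O)c1)c1ccc(Cl)cc1` gives 11000 nM in this assay.

Among these three numbers compound 1 stands second highest: its nearest neighbour is compound 3, with a 1.2-fold higher number from compound 1 to compound 3 (0.07 log units; within the scatter), and its furthest is compound 2, with a 4.0-fold lower number from compound 1 to compound 2 (0.60 log units; beyond the scatter). Compound 4 `O=C(Nc1cccc(-c2oc3cc(-c4ccc(F)cc4)ccc3c(=O)c2O)c1)c1cc(F)cc(F)c1` has not yet been measured. It differs from compound 1 in one place: 3,5-difluorophenyl in place of 4-fluorophenyl on a carbonyl carbon. This is the same carbonyl carbon, attached to the amide-type nitrogen, at which compound 2 and compound 3 also differ from compound 1. There, methyl in place of fluoro gave a modest step, a 4.0-fold lower number from compound 1 to compound 2 (0.60 log units; beyond the scatter); chloro in place of fluoro gave a 1.2-fold higher number from compound 1 to compound 3 (0.07 log units; within the scatter), within the scatter; and from compound 2 to compound 3 the step was a 4.7-fold higher number from compound 2 to compound 3 (0.68 log units; beyond the scatter). None of these steps adds a second fluorine or changes where the fluorine sits, so they offer no direct guide. A step no larger than the scatter is therefore expected, a 1.0-fold lower number from compound 1 to compound 4 (0.01 log units; within the scatter). Compound 4 is estimated at 9000 nM, within a range of 3000 nM to 27000 nM.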

Compound 4, half-maximal inhibitory concentration: 4960 nM
Compound 4: middle estimate off by 1.8-fold (0.26 log units), on the high side; low and high end bracket the measured number.
By their numbers in this assay, from the lowest: compound 2; then compounds 4, 1 and 3 (each within the scatter of the next, the first and the last beyond it).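

Among these compounds, the 3,5-difluorophenyl group is the first change at this carbonyl carbon to alter both the number and the placement of the fluorines, and in this assay it stays within the scatter of 4-fluorophenyl (a 1.9-fold lower number from compound 1 to compound 4 (0.27 log units; within the scatter)). Even so, it stands apart from the other two groups (a 2.2-fold lower number from compound 3 to compound 4 (0.35 log units; beyond the scatter); a 2.1-fold higher number from compound 2 to compound 4 (0.33 log units; beyond the scatter)), which places compound 4 in the middle of the set and leaves compound 2, with its 4-methylphenyl group, with the lowest number. Nothing given here explains these differences.

From the compounds shown here alone, what 3-fluorophenyl alone or 3,5-dimethylphenyl would give at this carbonyl carbon remains open, so the two changes in compound 4, a second fluorine and a new placement, cannot be told apart. Going by these compounds, how an amine or a carboxylic acid on this ring would read also stays unknown.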